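A Chloro Added to Compound 3

A few compounds are considered here, and "the series" means these few. Any claim that something is new, unique, unknown or untested is made for them only; others in the source may bear on it.

- compound 1 `CCOC(=O)/C=C/C=C/C=C/C=C/c1ccc[nH]1`: 1340 nM
- compound 2 `CCOC(=O)/C=C/C=C/C=C/c1[nH]ccc1Cl`: 2420 nM
- compound 3 `O=C(/C=C/C=C/C=C/C=C/c1ccc[nH]1)OCc1ccccc1`: 190 nM

In a functional assay on CCRF-CEM cells (Homo sapiens) for cytotoxicity, with a stated time of 72 h (a lower number here means a stronger inhibitor, a higher number a weaker inhibitor), compound 3 gives the lowest of the three numbers. Among the compounds with values here, the only measured single change is the step of a 7.1-fold lower number from compound 1 to compound 3 (0.85 log units; beyond the scatter), which puts phenyl in place of methyl on a chain carbon.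

The next compound, compound 4 `O=C(/C=C/C=C/C=C/C=C/c1[nH]ccc1Cl)OCc1ccccc1`, keeps compound 3 intact except for one change: chloro in place of hydrogen on an aromatic carbon. The measured step lies at a different place in the molecule, so it offers no direct guide to this change.

The closest hint comes from compound 2, which carries the same chloro but also differs from compound 1 in its chain. Here compound 2 gives 2420 nM and compound 1 gives 1340 nM, two values within the usual scatter of each other. Within the data shown here, no measured pair isolates the chloro, so this hint is weak, and it points to little change.

The expected change is a 1.3-fold higher number from compound 3 to compound 4 (0.10 log units; within the scatter), which would be no clear step beyond the scatter. Compound 4 is therefore estimated at about 240 nM, with an expected range of 80 nM to 750 nM.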

Compound 4, half-maximal inhibitory concentration: 280 nM
Beside the measured number, compound 4's estimate is 1.2-fold (0.07 log units) below it; measured number inside the range.
By their numbers in this assay, from the lowest: compounds 3 and 4 (each within the scatter of the next); then compounds 1 and 2 (each within the scatter of the next).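

Chloro in place of hydrogen on an aromatic carbon, next to the ring atom that bears a large group and two ring bonds from the ring nitrogen, gives a 1.5-fold higher number from compound 3 to compound 4 (0.17 log units; within the scatter) in this assay. Within the data shown here, this is the first pair that isolates the chloro, as compound 2 carries the same group but also differs from compound 1 in its chain, so the effect of chloro could not be read from those two compounds alone. At this ring position, with the rest of compound 3 held constant, a single chlorine atom can replace hydrogen without a step beyond the scatter, although no measurement shown here accounts for that result.

The compounds shown leave open whether bromo, methyl or methoxy on this same carbon would also stay within the scatter, and whether chloro on another ring carbon would behave in the same way. They also leave open whether chloro would give a similar step on the chain of compound 1, whose ester ends in methyl rather than phenyl.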